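The compounds below may be only part of what the source reports. "The series", "measured", "known", "first", "only" and "open" are said of these compounds alone.

Measured in a functional assay on K562 cells (Homo sapiens) for inhibition, read by MTT assay, with a stated time of 72 h; a higher number here means a weaker inhibitor, a lower number a stronger inhibitor:

Compound 1, `CC(C)c1cc(C(C)C)c(C(=O)/C=C/C(=O)O)c(C(C)C)c1`: 4670 nM
Compound 2, `CCc1cc(CC)c(C(=O)/C=C/C(=O)O)c(CC)c1`: 4010 nM
Compound 3, `CC(C)(C)c1ccc(C(=O)/C=C/C(=O)O)cc1`: 4330 nM

All three measured compounds share the same core, an unsaturated keto acid chain attached to a benzene ring, and differ only in the alkyl groups on that ring. Their numbers in this assay lie close together: compound 3 sits between compound 1 and compound 2, and both of those neighbours are within the usual scatter of it. On these numbers, then, no one of the three can be set apart from the others, and the alkyl pattern on the ring seems to matter little here.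

Compound 4, `O=C(O)/C=C/C(=O)c1ccc(Cl)cc1`, has not yet been measured. It differs from compound 3 in one place: chloro in place of tert-butyl on an aromatic carbon. Going by the values given here, since no measured pair shows this kind of change, there is no direct guide to its effect. Given how little the three alkyl variations moved the numbers, the step from compound 3 to compound 4 in this assay is expected to be small, plausibly within the scatter, with perhaps a slight drift toward a higher number; the expected step is a 1.3-fold higher number from compound 3 to compound 4 (0.10 log units; within the scatter). Compound 4 is therefore estimated at 5500 nM, within a range of 2000 nM to 15000 nM.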

Compound 4, half-maximal inhibitory concentration: 21700 nM
Compound 4: the middle estimate sits 3.9-fold (0.60 log units) below what was measured; measured number above the stated range.
By their numbers in this assay, from the lowest: compounds 2, 3 and 1 (each within the scatter of the next); then compound 4.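

In this assay, putting chloro in place of tert-butyl on the aromatic carbon para to a group of 7 heavy atoms gives a 5.0-fold higher number from compound 3 to compound 4 (0.70 log units; beyond the scatter) and this step lies beyond the scatter, so what sits on this carbon can change the number. The earlier compounds shown here could not show this: they carry different alkyl patterns, their numbers lie within the scatter of one another, and no two of them differ in only one place, which left the near-equal values with no single change to read. The data shown offer no measurement of any property that could account for the step, so its cause stays unknown.

From the compounds shown here alone, this single step cannot separate the departure of tert-butyl from the arrival of chloro, so it remains open which of the two drives the change. A plain hydrogen, a methyl group, a bromo group or an amine on the same carbon would help to decide that, and would show whether chloro stands alone or belongs to a wider trend.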